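This account rests on a few compounds, and the source may have more. Where it says the series, first, only, none or still open, it means among the compounds named here.

Of the compounds shown here, three of one series have been tested in a functional assay, read by spectrophotometry, with a stated time of 1 h (on this read-out lower numbers stand for stronger inhibition and higher numbers for weaker inhibition), and none of them shows a clear effect. Compound 1, `N/N=C\c1cc(=O)oc2cc(OCc3ccccc3)cc(OCc3ccccc3)c12`, gives > 2000000 nM, which is a limit of the assay rather than a measured number. That limit is set out as the limit of > 2000000 nM in this assay, at which 1 of the 3 values shown sits, and it belongs to compound 1 alone. Compound 2, `N/N=C\c1cc(=O)oc2cc(OCc3ccccc3)ccc12`, is recorded as "not active" (no number reported), with no number attached. Compound 3, `O=c1cc(-c2nc3ccccc3[nH]2)c2ccc(OCc3ccccc3)cc2o1`, is likewise recorded as "not active" (no number reported). So compound 2 stands among values none of which is a plain figure: one is a limit, another is an entry without a number, and compound 2 itself has none.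

Compound 4, `O=c1cc(/C=N\Nc2ccc([N+](=O)[O-])cc2)c2ccc(OCc3ccccc3)cc2o1`, is the next member and has not yet been measured in this assay. It is related to compound 2 by a single change, (4-nitrophenyl in place of hydrogen on an amine nitrogen). For the measured compounds named here, no step between two measured compounds is on record, so the size of such a change cannot be read from a like example. Compound 2 shows no measurable effect, and compound 1 and compound 3 show none either. On that footing compound 4 is expected to sit at the weak end as well, with no shift beyond the scatter, and is estimated at 500000 nM, within 50000 nM and 5000000 nM, with a real chance that only a limit is reported.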

Compound 4, half-maximal inhibitory concentration: > 2000000 nM
Compound 4: only a limit was reported; the forecaster's own chance of this, stated with the estimate: 70%; middle value at least 4.0-fold (0.60 log units) away from the limit.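

Compound 4 gives > 2000000 nM, which is a limit and not a measured number. For the compounds shown here, compound 2 has no number at all, so no step from it to compound 4 can be read. The compounds shown leave open which change to the shared core, if any, would give measurable inhibition in this assay.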